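A 4-Nitrophenyl Group Replaces Dimethylamino on the Sulfonyl Sulfur

This account rests on a few compounds, and the source may have more. Where it says the series, first, only, none or still open, it means among the compounds named here.

Three compounds sharing one core, which differ in the group on an amine nitrogen in a ring, have been measured in a functional assay on HCT-116 cells (Homo sapiens) for cytotoxicity, read by sulforhodamine B assay, with a stated time of 48 h; on this read-out higher numbers stand for weaker inhibition and lower numbers for stronger inhibition. There, compound 1 (`CC(=O)n1nc(NC(=O)c2ccccc2)c2c1CN(C(=O)C1CCC(C)CC1)C2`) gives 12200 nM, compound 2 (`CC(=O)n1nc(NC(=O)c2ccccc2)c2c1CN(C(=O)c1cccc(F)c1)C2`) gives 21900 nM and compound 3 (`CC(=O)n1nc(NC(=O)c2ccccc2)c2c1CN(S(=O)(=O)N(C)C)C2`) gives 35300 nM. Compound 3 stands clear of compound 1 but not of compound 2, with a 1.6-fold higher number from compound 2 to compound 3 (0.21 log units; within the scatter).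

Compound 4 (`CC(=O)n1nc(NC(=O)c2ccccc2)c2c1CN(S(=O)(=O)c1ccc([N+](=O)[O-])cc1)C2`) is the next to be read. It has 4-nitrophenyl in place of dimethylamino on a sulfonyl sulfur, and the change counts as 4-nitrophenyl in place of dimethylamino on a sulfonyl sulfur. Among the measured compounds shown here, no measured step makes this exchange, so the evidence is indirect. The steps among the measured compounds are small: a 1.8-fold higher number from compound 1 to compound 2 (0.25 log units; within the scatter), and the largest of them, a 2.9-fold higher number from compound 1 to compound 3 (0.46 log units; beyond the scatter), is only modest. On that basis, no change beyond the scatter is expected in this assay, with a slight drift towards a lower number as the more likely direction. The expected step is a 1.4-fold lower number from compound 3 to compound 4 (0.13 log units; within the scatter). The estimate for compound 4 is 26000 nM, with an expected range from 11000 nM to 55000 nM.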

Compound 4, half-maximal inhibitory concentration: 22300 nM
Compound 4: the middle estimate sits 1.2-fold (0.07 log units) above what was measured; measured number inside the range.
By their numbers in this assay, from the lowest: compounds 1, 2, 4 and 3 (each within the scatter of the next, the first and the last beyond it).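

Among the compounds shown here, the earlier steps all changed the whole group on the ring nitrogen, so this is the first look at the substituent on the sulfonyl sulfur with the sulfonyl itself kept in place. In this assay the exchange gives a 1.6-fold lower number from compound 3 to compound 4 (0.20 log units; within the scatter) and so shows that this place accepts a much larger substituent with no resolvable change in the read-out: dimethylamino, with 3 heavy atoms and no ring, gives way to 4-nitrophenyl, with 9 heavy atoms, a six-membered aromatic ring and 2 hydrogen-bond acceptors. This holds for this single pair only, and no measurement is available that would explain the outcome.

The compounds shown do not separate the contribution of the aromatic ring from that of the nitro group, which a plain phenyl or a 4-aminophenyl group on the sulfonyl sulfur would address. They also leave open whether a small methyl or a cyclic amine such as morpholine at this place would move the number beyond the scatter in either direction.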